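Changing One Aryl Ring: From Compound 3 to Compound 4

The source may hold more compounds than are shown below. What is called first, only, known or untested is meant among the compounds shown, and "the series" means these compounds.

Measured so far in an assay on cells for agonist activity at ecdysone receptor (Bombyx mori), read by a luciferase reporter, with a stated time of 24 h; on this read-out lower numbers stand for an effect already at smaller amounts and higher numbers for an effect only at larger amounts of compound:
- compound 1, `CC(C)(C)N(NC(=O)c1ccccc1)C(=O)c1ccccc1I`, gives 105 nM
- compound 2, `CC(C)(C)N(NC(=O)c1ccccc1)C(=O)c1ccc(Cl)cc1Cl`, gives 117 nM
- compound 3, `CC(C)(C)N(NC(=O)c1ccccc1F)C(=O)c1ccccc1Cl`, gives 51.3 nM

Compound 3 has the lowest of the three numbers, and its distance from both compound 1 and compound 2 lies beyond the usual scatter, so it is the most potent of the measured set. Compound 1 and compound 2 are close to each other: a 1.1-fold higher number from compound 1 to compound 2 (0.05 log units; within the scatter).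

Compound 4, `CC(C)(C)N(NC(=O)c1ccc(Cl)cc1)C(=O)c1ccccc1Cl`, differs from compound 3 in one place: 4-chlorophenyl in place of 2-fluorophenyl on a carbonyl carbon. For the measured compounds named here, the only measured step available, the one from compound 1 to compound 2, concerns a halogen change on the other carbonyl carbon and was within the scatter. Going by the values given here, no measured pair tests a change on the carbonyl carbon where compound 4 differs, so that step offers only a loose hint that swapping one halogenated ring for another need not shift the number much.

Given that, compound 4 is expected to land near compound 3, perhaps somewhat higher, with a step of a 1.6-fold higher number from compound 3 to compound 4 (0.19 log units; within the scatter). The estimate for compound 4 is 80 nM, in a range from 30 nM to 250 nM.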

Compound 4, half-maximal effective concentration: 115 nM
Estimate against measurement, compound 4: 1.4-fold (0.16 log units) below; the range from low to high includes it.
By their numbers in this assay, from the lowest: compound 3; then compounds 1, 4 and 2 (each within the scatter of the next).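

For the compounds shown here, this is the first measured sign that the ring on this carbonyl carbon can change the result: in this assay, 4-chlorophenyl in place of 2-fluorophenyl gives a 2.2-fold higher number from compound 3 to compound 4 (0.35 log units; beyond the scatter), a modest step but one that lies beyond the usual scatter, whereas the one earlier step, a 1.1-fold higher number from compound 1 to compound 2 (0.05 log units; within the scatter), involved a change elsewhere in the molecule and stayed within it. The swap changes both the halogen, from fluorine to chlorine, and its location on the ring, while the computed counts of heavy atoms, hydrogen-bond donors and hydrogen-bond acceptors are the same for the two groups, so those counts do not separate them. Nothing measured here accounts for the shift in the number.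

Going by these compounds alone, the single step cannot show whether the halogen or its location matters, and a 4-fluorophenyl group at this place would help separate the two. From the compounds shown here alone, it also remains open how this carbonyl carbon would tolerate a ring carrying something other than a halogen, such as a methoxy group, an amine or a carboxylic acid.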